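This account rests on a few compounds, and the source may have more. Where it says the series, first, only, none or still open, it means among the compounds named here.

Within the data shown here, compound 1, `CCCCCc1c(C(C)C)nc(C(C)C)c(CO)c1-c1ccc(O)cc1`, is one of only two compounds measured in an assay on CHO cells for inhibition of Glucagon receptor (Homo sapiens), tested at 20 uM; a higher number here means more inhibition at the concentration tested (going by the name of the read-out), a lower number less inhibition. In this assay compound 1 gives 24%, while its companion compound 2, `CCCCCc1c(C(C)C)nc(C(C)C)c(CO)c1-c1ccc2ccccc2c1`, gives 16%; the two numbers sit within the usual scatter of each other, so neither stands apart, and both point to modest inhibition at the concentration tested. Compound 3, `CCCCCc1c(C(C)C)nc(C(C)C)c(CO)c1-c1ccccc1OC`, has not yet been measured. It differs from compound 1 in a single place: 2-methoxyphenyl in place of 4-hydroxyphenyl on an aromatic carbon. Among the measured compounds shown here, no measured pair shows how such a change plays out on the shared core, so the expectation can rest only on the low numbers from compound 1 and compound 2. The step from compound 1 to compound 3 is expected to be small, a number 8 percentage points lower from compound 1 to compound 3 (within the scatter), leaning slightly downward but not clearly beyond the scatter. For compound 3 the estimate in this assay is therefore 16%, within a range from 0% to 35%.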

Compound 3, a percentage reported as inhibition, at one concentration (the size of the read-out at that concentration, not a potency): 27%
For compound 3 the middle estimate is 11 percentage points below the measured one, within the range that was stated.
By their numbers in this assay, from the lowest: compounds 2, 1 and 3 (each within the scatter of the next, the first and the last beyond it).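

In this assay, putting 2-methoxyphenyl in place of 4-hydroxyphenyl on the aromatic carbon opposite the ring nitrogen gives a number 3 percentage points higher from compound 1 to compound 3 (within the scatter), the first step measured at this position. The position therefore keeps its modest read-out when the single hydrogen-bond donor of 4-hydroxyphenyl is gone and the oxygen-bearing group is a 2-methoxy rather than a 4-hydroxy substituent. Nothing available explains this result.

Since the oxygen's substituent and its place on the aromatic group change together, this one step cannot separate the two, and 4-methoxyphenyl or 2-hydroxyphenyl would be needed to do so. From the compounds shown here alone, it also remains open whether 4-aminophenyl or 4-carboxyphenyl at this position would move the inhibition beyond the scatter.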